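This account rests on a few compounds, and the source may have more. Where it says the series, first, only, none or still open, it means among the compounds named here.

Of the compounds shown here, three from this series have been measured in an assay on microsomes from liver for inhibition of 3-hydroxy-3-methylglutaryl-coenzyme A reductase (Rattus norvegicus); on this read-out higher numbers stand for weaker inhibition and lower numbers for stronger inhibition. Compound 1 `COc1cccc(-c2nc(C(F)(F)F)n(CC[C@@H](O)C[C@@H](O)CC(=O)O)c2-c2ccc(F)cc2)c1` gives 20 nM in this assay. Compound 2 `Cc1cc(C)cc(-c2c(-c3ccc(F)cc3)nc(C(F)(F)F)n2CC[C@@H](O)C[C@@H](O)CC(=O)O)c1` gives 38 nM. Compound 3 `CC(C)c1nc(-c2ccc(F)cc2)c(-c2cc(Cl)cc(Cl)c2)n1/C=C/[C@@H](O)C[C@@H](O)CC(=O)O` gives 22 nM, which is the second highest of the three numbers; its nearest neighbour is compound 1 and its furthest is compound 2, and both gaps lie within the usual scatter, so all three compounds read as equally strong inhibitors here.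

Compound 4 `Cc1cc(C)cc(-c2c(-c3ccc(F)cc3)nc(C(C)C)n2/C=C/[C@@H](O)C[C@@H](O)CC(=O)O)c1` is made from compound 3 by one change: 3,5-dimethylphenyl in place of 3,5-dichlorophenyl on an aromatic carbon. Going by the values given here, no measured pair in this set differs in exactly this way, so the step has to be judged from what is at hand. Compound 2 carries the same 3,5-dimethylphenyl group and gives 38 nM, a number within the scatter of what compound 3 shows. The step from compound 3 to compound 4 is therefore expected to be small, within the scatter, with no clear direction, as a 1.4-fold higher number from compound 3 to compound 4 (0.13 log units; within the scatter). Compound 4 is estimated at 30 nM, with a range from 12 nM to 75 nM.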

Compound 4, half-maximal inhibitory concentration: 56 nM
For compound 4 the middle estimate is 1.9-fold (0.27 log units) below the measured one; the range from low to high includes it.
By their numbers in this assay, from the lowest: compounds 1, 3, 2 and 4 (each within the scatter of the next, the first and the last beyond it).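

On the aromatic carbon next to the ring nitrogen, 3,5-dimethylphenyl in place of 3,5-dichlorophenyl proves not to be a neutral swap in this assay: the change gives a 2.5-fold higher number from compound 3 to compound 4 (0.41 log units; beyond the scatter) and counts as a modest step. Going by these compounds alone, the two groups have the same number of heavy atoms and neither has hydrogen-bond donors or acceptors, so these counts do not separate them, and the earlier compounds offered no pair that differs in one place. Nothing available here explains the size or direction of this step.

This single pair leaves open whether the step would look the same with trifluoromethyl in place of isopropyl on the core. It also leaves open how an unsubstituted phenyl or a 3,5-difluorophenyl group would compare at this position.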